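The compounds below may be only part of what the source reports. "The series", "measured", "known", "first", "only" and "open" are said of these compounds alone.

Three compounds were tested in an ADME assay on HEK293 cells (Homo sapiens) for cytotoxicity, read by resazurin assay, with a stated time of 48 h; a lower number here means that less compound is tolerated, a higher number that more compound is tolerated. Compound 1 `O=S(=O)(Nc1ccc2oc(-c3ccccc3)nc2c1)c1cccc(C(F)(F)F)c1` gave only a limit of the assay in this assay, > 100000 nM. Compound 2 `Cc1cccc(S(=O)(=O)Nc2ccc3oc(-c4ccccc4)nc3c2)c1` gave a number, 69000 nM, in this assay. Compound 3 `Cc1ccccc1S(=O)(=O)Nc1ccc(-c2nc3ccccc3o2)cc1` likewise returned only a limit in this assay, > 100000 nM. The difference between the core of compound 2 and the core of compound 3 is not broken down here. Among the compounds with values here, the one measured step, an at least 1.4-fold higher number from compound 2 to compound 1 (0.16 log units; that floor lies within the scatter), comes from the change (trifluoromethyl in place of methyl on an aromatic carbon).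

Compound 4 `O=S(=O)(Nc1ccc(-c2nc3ccccc3o2)cc1)c1ccccc1C(F)(F)F` is not yet measured. The change from compound 3 to it is trifluoromethyl in place of methyl on an aromatic carbon. It is the same kind of change as that from compound 2 to compound 1, but the place differs: there the trifluoromethyl stands meta to a large group, here ortho to a large group. Because compound 3 already sits at the limit (the limit of > 100000 nM in this assay, at which 2 of the 3 values shown sit), and because the earlier step of an at least 1.4-fold higher number from compound 2 to compound 1 (0.16 log units; that floor lies within the scatter) did not lower the number, compound 4 is expected to sit at that limit too, with the estimated step that the limit leaves unreadable from compound 3 to compound 4. The estimate for compound 4 in this assay is 150000 nM, between 60000 nM and 400000 nM.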

Compound 4, half-maximal cytotoxic concentration: > 100000 nM
Compound 4 gave a limit, no number; the forecaster's own chance of this, stated with the estimate: 80%; the middle value lies beyond the limit too.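

Within the data shown here, compound 3 and compound 4 both returned only a limit of the assay in this assay, and no step between them can be read: the limit of > 100000 nM in this assay, at which 3 of the 4 values shown sit. The compounds shown leave open what number compound 3 and compound 4 would give, and whether trifluoromethyl in place of methyl, ortho to a large group, changes it at all.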